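Swapping dipropylamino for dibutylamino on compound 3

The source may hold more compounds than are shown below. What is called first, only, known or untested is meant among the compounds shown, and "the series" means these compounds.

In a functional assay (aorta) with Rattus norvegicus as the target (a lower number here means a stronger inhibitor, a higher number a weaker inhibitor), compound 3 `CCCN(CCC)CCCOc1ccc(S(=O)(=O)c2c(CC)cn3ccccc23)cc1` gives 150 nM. That lies within the usual scatter of compound 1 `CCCCc1cn2ccccc2c1S(=O)(=O)c1ccc(OCCCN(CCCC)CCCC)cc1` at 284 nM. Compound 2 `CCCCN(CCCC)CCCOc1ccc(S(=O)(=O)c2c(C3CCCCC3)cn3ccccc23)cc1` gives 4070 nM, and its gap to compound 3 lies beyond the scatter. Compound 4 `CCCCN(CCCC)CCCOc1ccc(S(=O)(=O)c2c(CC)cn3ccccc23)cc1` has not been measured yet and differs from compound 3 in one place: dibutylamino in place of dipropylamino on a saturated chain carbon, three bonds along the chain from an oxygen on an aromatic ring.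

Among the measured compounds shown here, no measured step covers this swap. For the measured compounds named here, the only step available, a 14-fold higher number from compound 1 to compound 2 (1.16 log units; beyond the scatter), is large, but it puts cyclohexyl in place of butyl on an aromatic carbon, a different place in the molecule, so it says little about this change. Going by the values given here, the closest hint is that compound 1, which also carries dibutylamino, gives 284 nM, a value within the scatter of the one for compound 3.

In this assay, the expected result is no step beyond the scatter, with an estimated 1.3-fold higher number from compound 3 to compound 4 (0.10 log units; within the scatter). The estimate for compound 4 is 190 nM, with an expected range from 70 nM to 500 nM.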

Compound 4, half-maximal inhibitory concentration: 31.3 nM
Compound 4: middle estimate off by 6.1-fold (0.78 log units), on the high side; measured number outside the range, below it.
By their numbers in this assay, from the lowest: compound 4; then compounds 3 and 1 (each within the scatter of the next); then compound 2.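

In this assay, among the compounds shown here, the amine end of the side chain turns out to matter, since dibutylamino in place of dipropylamino gives a 4.8-fold lower number from compound 3 to compound 4 (0.68 log units; beyond the scatter), a change no earlier pair could show. With dibutylamino held fixed, the group on the aromatic carbon now forms a series of three: butyl to ethyl gives a 9.1-fold lower number from compound 1 to compound 4 (0.96 log units; beyond the scatter), and cyclohexyl to ethyl gives a 130-fold lower number from compound 2 to compound 4 (2.11 log units; beyond the scatter), so among these compounds ethyl gives the lowest number and cyclohexyl the highest. Nothing available here accounts for either trend.

From the compounds shown here alone, whether the number keeps falling with a longer chain on the nitrogen, such as dipentylamino, or turns back up remains open. So does the outcome with methyl on the aromatic carbon, or with the nitrogen held in a piperidine ring.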